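The source may report more compounds than this note shows. Statements on the series, on what has been measured and on what is new or still open speak of the compounds shown alone.

Measured compounds:
Compound 1 `CS(=O)(=O)c1ccc(-c2cc(C(=O)N[C@H]3CCCNC3)c(NC(N)=O)s2)cc1`: in a functional assay on HT-29 cells (Homo sapiens) (a lower number here means that less compound is needed, a higher number that more compound is needed for the effect), compound 1 gives 200 nM.
Compound 2 `Cc1ccc(-c2cc(C(=O)N[C@H]3CCCNC3)c(NC(N)=O)s2)cc1`: in this assay compound 2 gives 70 nM.
Compound 3 `NC(=O)Nc1sc(-c2ccc(C(=O)N3CCCCC3)cc2)cc1C(=O)N[C@H]1CCCNC1`: in this assay compound 3 gives 130 nM.

Compound 3 has the second highest of the three numbers. Its distance to the other two is small: a 1.5-fold lower number from compound 1 to compound 3 (0.19 log units; within the scatter) and a 1.9-fold higher number from compound 2 to compound 3 (0.27 log units; within the scatter) both lie within the scatter, so no order among these three can be claimed. Among the measured compounds shown here, the only step beyond the scatter is a 2.9-fold lower number from compound 1 to compound 2 (0.46 log units; beyond the scatter).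

Compound 4 `NC(=O)Nc1sc(-c2ccc(C(N)=O)cc2)cc1C(=O)N[C@H]1CCCNC1` differs from compound 3 in one place: amino in place of piperidin-1-yl on a carbonyl carbon. All three measured steps exchange the group on this same aromatic carbon of the shared core, and even the largest of them was only modest, while the others stayed within the scatter. The change from compound 3 to compound 4 keeps the carbonyl and trims only what hangs on it, so the expected step is small, no change at the digits printed from compound 3 to compound 4 (within the scatter), in no clear direction. Compound 4 is therefore expected to give about 130 nM in this assay, estimated between 50 nM and 350 nM.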

Compound 4, half-maximal effective concentration: 3200 nM
Beside the measured number, compound 4's estimate is 25-fold (1.39 log units) below it; measured number outside the range, above it.
By their numbers in this assay, from the lowest: compounds 2, 3 and 1 (each within the scatter of the next, the first and the last beyond it); then compound 4.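

So far, exchanging the group on this aromatic carbon had moved the number in this assay only modestly at most, but a 25-fold higher number from compound 3 to compound 4 (1.39 log units; beyond the scatter) shows that the position is far from indifferent. The carbonyl stays and only what hangs on it changes, yet much more compound is needed for the effect. Carbamoyl also stands apart from the other two groups, with a 46-fold higher number from compound 2 to compound 4 (1.66 log units; beyond the scatter) and a 16-fold higher number from compound 1 to compound 4 (1.20 log units; beyond the scatter) as the steps, and nothing shown here explains this large loss.

The compounds shown leave open how the number changes on the way from amino to piperidin-1-yl, which a methylamino or dimethylamino group on the same carbonyl carbon would help to show. They also leave open whether a carboxylic acid on the aromatic carbon would behave like carbamoyl.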